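A dimethylaminomethyl group in place of propoxymethyl

A few compounds are considered here, and "the series" means these few. Any claim that something is new, unique, unknown or untested is made for them only; others in the source may bear on it.

Three compounds share one core. In a functional assay on HeLa cells (Homo sapiens) for cytotoxicity, read by neutral red uptake, with a stated time of 3 days (a higher number here means a weaker inhibitor, a lower number a stronger inhibitor), compound 1 `CCOC(=O)c1c(F)c(N)c2c(=O)cc(-c3ccc(N)c(F)c3)oc2c1F` reaches only a limit, > 100000 nM. In this assay compound 2 `CN(C)CCCC(=O)OCc1c(F)c(N)c2c(=O)cc(-c3ccc(N)c(F)c3)oc2c1F` gives 4500 nM, the step of an at least 22-fold lower number from compound 1 to compound 2 (1.34 log units; beyond the scatter). In this assay compound 3 `CCCOCc1c(F)c(N)c2c(=O)cc(-c3ccc(N)c(F)c3)oc2c1F` gives 78000 nM, the step of an at least 1.2-fold lower number from compound 1 to compound 3 (0.10 log units; that floor lies within the scatter). Among the two numbers compound 3 stands highest, with compound 2 nearest: a 17-fold higher number from compound 2 to compound 3 (1.24 log units; beyond the scatter).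

Compound 4 `CN(C)Cc1c(F)c(N)c2c(=O)cc(-c3ccc(N)c(F)c3)oc2c1F` differs from compound 3 by dimethylamino in place of propoxy on a saturated chain carbon bound to an aromatic carbon. Within the data shown here, two measured steps bear on this change. When a chain carrying dimethylamino entered, the number fell: an at least 22-fold lower number from compound 1 to compound 2 (1.34 log units; beyond the scatter). When that chain left, the number rose: a 17-fold higher number from compound 2 to compound 3 (1.24 log units; beyond the scatter). Compound 4 also brings dimethylamino onto the saturated chain carbon, though without the carbonyl and oxygen of compound 2, so the step is expected to run downward and to be large, though perhaps not as large as from compound 2. The expected step is an 11-fold lower number from compound 3 to compound 4 (1.05 log units; beyond the scatter). Compound 4 is therefore estimated at 7000 nM in this assay, within 1500 nM to 35000 nM.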

Compound 4, half-maximal inhibitory concentration: 8900 nM
Compound 4: middle estimate off by 1.3-fold (0.10 log units), on the low side, within the range that was stated.
By their numbers in this assay, from the lowest: compounds 2 and 4 (each within the scatter of the next); then compound 3. At a limit, above all of these: compound 1.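

Compound 4 shows that dimethylamino set directly on the saturated chain carbon is enough to lower the number in this assay, an 8.8-fold lower number from compound 3 to compound 4 (0.94 log units; beyond the scatter), and that the carbonyl and oxygen of compound 2 are not needed for this, a 2.0-fold higher number from compound 2 to compound 4 (0.30 log units; within the scatter). Measured against the ethoxycarbonyl of compound 1, (dimethylamino)methyl gives an at least 11-fold lower number from compound 1 to compound 4 (1.05 log units; beyond the scatter). Compound 1 stands at a limit, so that step is only a floor: the limit of > 100000 nM in this assay, at which 1 of the 4 values shown sits.

As far as these compounds go, it remains open whether the nitrogen must carry both methyl groups, as a primary amine or a morpholine ring in its place would test. A longer chain between the nitrogen and the aromatic carbon could also move the number in either direction.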